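The source may report more compounds than this note shows. Statements on the series, on what has been measured and on what is new or still open speak of the compounds shown alone.

In a functional assay on HCT-116 cells (Homo sapiens) for antiproliferative activity, read by WST assay, with a stated time of 72 h (a lower number here means a stronger inhibitor of growth, a higher number a weaker inhibitor of growth), compound 1 (`N#Cc1ccc(CN[C@H]2[C@@H]3CN(c4ncc(C(=O)NO)cn4)C[C@@H]32)cc1`) gives 270 nM and compound 2 (`O=C(NO)c1cnc(N2C[C@@H]3[C@H](C2)[C@H]3NC(=O)c2ccc3ccccc3c2)nc1`) gives 410 nM in the same test. Among the compounds with values here, these two numbers lie within the scatter of each other, which places compound 1 level with the only other measured compound. Compound 3 (`O=C(NO)c1cnc(N2C[C@@H]3[C@H](C2)[C@H]3NCc2cc(F)cc(F)c2)nc1`) keeps the core of compound 1 but carries 3,5-difluorophenyl in place of 4-cyanophenyl on a saturated chain carbon bound to an amine nitrogen. Within the data shown here, no measured pair shows this change on its own. Compound 1 at 270 nM and compound 2 at 410 nM sit close together with different side groups, and on that basis no step beyond the scatter is expected in this assay, in either direction. The estimated step is small (a 1.1-fold higher number from compound 1 to compound 3 (0.05 log units; within the scatter)). For compound 3 the expected value is 300 nM, with an estimated range of 110 nM to 800 nM in this test.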

Compound 3, concentration for 50% growth inhibition: 200 nM
Compound 3: middle estimate off by 1.5-fold (0.18 log units), on the high side; the range from low to high includes it.
By their numbers in this assay, from the lowest: compounds 3, 1 and 2 (each within the scatter of the next, the first and the last beyond it).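

With compound 1 and compound 3, this assay now has its first pair that differs in one place, and exchanging 4-cyanophenyl for 3,5-difluorophenyl on a saturated chain carbon bound to an amine nitrogen gives a 1.4-fold lower number from compound 1 to compound 3 (0.13 log units; within the scatter) and so leaves the two compounds level. At this position, then, the nitrile with its triple bond and its hydrogen-bond acceptor can give way to two fluorine atoms with no step beyond the scatter, at least for this one pair of aromatic rings. Nothing available explains why the two groups read alike.

From the compounds shown here alone, whether a ring other than a six-membered aromatic ring of carbon only, such as a pyridine ring or a cyclohexyl group, would stay level in this place remains open. So does the reading of an unsubstituted phenyl group there.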